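The compounds below may be only part of what the source reports. "The series", "measured", "known", "first", "only" and "open" are said of these compounds alone.

- compound 1 `NC(=O)[C@@H]1[C@H](Nc2nc(Nc3cccc(C(=O)N4CCCC4)c3)ncc2-c2ccccc2F)[C@H]2C=C[C@@H]1C2`: 130 nM
- compound 2 `NC(=O)[C@@H]1[C@H](Nc2nc(Nc3cccc(C(=O)N4CCCC4)c3)ncc2-c2ccnc(F)c2)[C@H]2C=C[C@@H]1C2`: 100 nM

In a functional assay on THP-1 cells (Homo sapiens) for inhibition, read by ELISA, with stated times of 1 h and 18 h (a higher number here means a weaker inhibitor, a lower number a stronger inhibitor), compound 2, at 100 nM, cannot be separated from compound 1, as the two lie within the scatter. Compound 3 `N#Cc1ccc(-c2cnc(Nc3cccc(C(=O)N4CCCC4)c3)nc2N[C@H]2[C@@H](C(N)=O)[C@@H]3C=C[C@H]2C3)cc1` changes one group of compound 2: 4-cyanophenyl in place of 2-fluoropyridin-4-yl on an aromatic carbon. For the measured compounds named here, only one measured step bears on this place: a 1.3-fold lower number from compound 1 to compound 2 (0.11 log units; within the scatter), for 2-fluoropyridin-4-yl in place of 2-fluorophenyl. Going by the values given here, no compound carrying 4-cyanophenyl has been measured, so the range stays wide. The expected change is small, a 1.2-fold higher number from compound 2 to compound 3 (0.08 log units; within the scatter), nothing beyond the scatter. The estimated value for compound 3 is 120 nM, with an expected range from 45 nM to 320 nM.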

Compound 3, half-maximal inhibitory concentration: 190 nM
Compound 3: the middle estimate sits 1.6-fold (0.20 log units) below what was measured, and the stated range covers the measured number.
By their numbers in this assay, from the lowest: compounds 2, 1 and 3 (each within the scatter of the next).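

Three different aromatic groups have now been compared at this position on the shared core, and in this assay no swap among them moves the number beyond the scatter: 4-cyanophenyl gives (a 1.9-fold higher number from compound 2 to compound 3 (0.28 log units; within the scatter)) against 2-fluoropyridin-4-yl and (a 1.5-fold higher number from compound 1 to compound 3 (0.16 log units; within the scatter)) against 2-fluorophenyl. A ring of carbon only that bears a nitrile therefore sits within the same band as the two fluorine-bearing rings. No measurement here offers an explanation for this.

From the compounds shown here alone, whether plain phenyl would stay in this band remains open. So does the outcome for a non-aromatic group here, such as an amine, a carboxylic acid or a longer chain.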